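Moving the fluorine on the aryl ring of compound 2

This account rests on a few compounds, and the source may have more. Where it says the series, first, only, none or still open, it means among the compounds named here.

The two measured compounds share one core and differ only in the aromatic ring attached to it. Compound 1 `COc1ccc2c(OCc3nnc4sc(-c5ccncc5)nn34)ccnc2c1` carries a pyridin-4-yl group, and in a functional assay on EBC-1 cells (Homo sapiens) for antiproliferative activity, with a stated time of 72 h (a lower number here means a stronger inhibitor, a higher number a weaker inhibitor), compound 1 gives 289 nM. Compound 2 `COc1ccc2c(OCc3nnc4sc(-c5ccc(F)cc5)nn34)ccnc2c1` carries a 4-fluorophenyl group instead, and in this assay compound 2 gives 187 nM. Among the compounds with values here, the single step between them, a 1.5-fold lower number from compound 1 to compound 2 (0.19 log units; within the scatter), is small, so compound 2 stands beside compound 1 rather than apart from it.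

Compound 3 `COc1ccc2c(OCc3nnc4sc(-c5cccc(F)c5)nn34)ccnc2c1` keeps the same atoms as compound 2 but rearranges them: 3-fluorophenyl in place of 4-fluorophenyl on an aromatic carbon. Within the data shown here, no measured step moves a fluorine around a phenyl ring; the only step available swapped one ring for another and stayed within the scatter. That gives no reason to expect more than a scatter-sized change here. Compound 3 is therefore estimated at 210 nM in this assay, with a range from 90 nM to 500 nM. This estimate means a step of a 1.1-fold higher number from compound 2 to compound 3 (0.05 log units; within the scatter), which is expected to lie within the scatter.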

Compound 3, half-maximal inhibitory concentration: 504 nM
For compound 3 the middle estimate is 2.4-fold (0.38 log units) below the measured one; measured number outside the range, above it.
By their numbers in this assay, from the lowest: compounds 2, 1 and 3 (each within the scatter of the next, the first and the last beyond it).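

Moving the fluorine without changing a single atom count is enough to shift the result in this assay (a 2.7-fold higher number from compound 2 to compound 3 (0.43 log units; beyond the scatter)), and this modest step is the only one among the three compounds that lies beyond the scatter. Replacing the whole ring is a larger change on paper, yet neither pyridin-4-yl to 4-fluorophenyl (a 1.5-fold lower number from compound 1 to compound 2 (0.19 log units; within the scatter)) nor pyridin-4-yl to 3-fluorophenyl (a 1.7-fold higher number from compound 1 to compound 3 (0.24 log units; within the scatter)) leaves the scatter, so at this position the place of one fluorine on the phenyl ring can count for more than the identity of the ring. No measurement shown here bears on why the two fluorophenyl groups differ.

The compounds shown leave open whether a 2-fluorophenyl group or a plain phenyl ring without fluorine would give a number closer to that of compound 2 or that of compound 3. From the compounds shown here alone, it also remains open whether the same preference would hold with a different atom or group in place of the fluorine, such as chlorine or methoxy, on this ring.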